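Para-substituent swap on the benzylidene hydrazide series

A few compounds are considered here, and "the series" means these few. Any claim that something is new, unique, unknown or untested is made for them only; others in the source may bear on it.

Measured compounds: compound 1 `Cc1ccc(/C=N/NC(=O)CSc2nnnn2C)cc1` gives 3160000 nM; compound 2 `Cn1nnnc1SCC(=O)N/N=C/c1ccc(Br)cc1` gives > 10000000 nM, a limit of the assay.

In a functional assay on A549 cells (Homo sapiens) for cytotoxicity, read by XTT assay, with a stated time of 24 h (a higher number here means a weaker inhibitor, a lower number a stronger inhibitor), compound 2 stands only at a limit (the limit of > 10000000 nM in this assay, at which 1 of the 2 values shown sits), with no number. From compound 1 to compound 2 the step was an at least 3.1-fold higher number from compound 1 to compound 2 (0.50 log units; beyond the scatter). Compound 3 `CN(C)c1ccc(/C=N/NC(=O)CSc2nnnn2C)cc1` differs from compound 2 by dimethylamino in place of bromo on an aromatic carbon. No measured step bears directly on this change; the single step shown runs from a methyl to a bromo, not into a dimethylamino, so its direction is not transferable. The estimated step of an at least 1.6-fold lower number from compound 2 to compound 3 (0.22 log units; that floor lies within the scatter) from compound 2 to compound 3 is therefore uncertain, with no clear direction beyond the scatter. Compound 3 is estimated at 6000000 nM, expected between 1500000 nM and 20000000 nM.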

Compound 3, half-maximal inhibitory concentration: 100000 nM
Estimate against measurement, compound 3: 60-fold (1.78 log units) above; the whole stated range lies above it.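

Dimethylamino on this aromatic carbon is the first change in the series to lower the number in this assay: a 32-fold lower number from compound 1 to compound 3 (1.50 log units; beyond the scatter), and an at least 100-fold lower number from compound 2 to compound 3 (2.00 log units; beyond the scatter). The second step is only a floor, since compound 2 stands at a limit: the limit of > 10000000 nM in this assay, at which 1 of the 3 values shown sits. Of the three groups at this place, dimethylamino alone counts a hydrogen-bond acceptor, but three compounds cannot tie the step to that count.

From the compounds shown here alone, whether the step belongs to the nitrogen or to dimethylamino as a whole stays open. A primary amine or a methoxy group on the same carbon would bear on this.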